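Chain extension at the hydroxycarbamoyl end of the series

The compounds below may be only part of what the source reports. "The series", "measured", "known", "first", "only" and "open" are said of these compounds alone.

Values so far in a functional assay on A-431 cells (Homo sapiens) for antiproliferative activity, read by MTT assay, with a stated time of 48 h (on this read-out higher numbers stand for weaker inhibition and lower numbers for stronger inhibition), for two compounds
- compound 1 `O=C(CCCCCC(=O)Nc1ccc(O)c(C(=O)Nc2cccc(C(F)(F)F)c2)c1)NO` gives 2750 nM
- compound 2 `C#Cc1cccc(NC(=O)c2cc(NC(=O)CCCCCC(=O)NO)ccc2O)c1` gives 5750 nM

For the measured compounds named here, compound 2 holds the higher of the two numbers (5750 nM), and the only measured step is modest and beyond the scatter: a 2.1-fold higher number from compound 1 to compound 2 (0.32 log units; beyond the scatter) for ethynyl in place of trifluoromethyl on an aromatic carbon. Compound 3 `C#Cc1cccc(NC(=O)c2cc(NC(=O)CCCCCCC(=O)NO)ccc2O)c1` has (hydroxycarbamoyl)methyl in place of hydroxycarbamoyl on a saturated chain carbon, five bonds along the chain from a carbonyl carbon. Going by the values given here, no measured step touches this chain, so the data set no direction. The aromatic step (a 2.1-fold higher number from compound 1 to compound 2 (0.32 log units; beyond the scatter)) serves only as a gauge of size. In this assay no shift clearly beyond the scatter is expected, with a slight lean to a lower number as judgement only. The estimated change is a 1.4-fold lower number from compound 2 to compound 3 (0.16 log units; within the scatter) in this read-out. Compound 3 is estimated at 4000 nM (expected range 1500 nM to 11000 nM).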

Compound 3, half-maximal inhibitory concentration: 6110 nM
Compound 3: middle estimate off by 1.5-fold (0.18 log units), on the low side; the measured number falls inside the stated range.
By their numbers in this assay, from the lowest: compound 1; then compounds 2 and 3 (each within the scatter of the next).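

In this assay, for the compounds shown here, (hydroxycarbamoyl)methyl in place of hydroxycarbamoyl on the saturated chain gives a 1.1-fold higher number from compound 2 to compound 3 (0.03 log units; within the scatter), so the first measured change at this position produces no shift that can be told from the scatter. With ethynyl on the aromatic carbon, the number at this position therefore does not respond to this extension, and the step from trifluoromethyl to ethynyl remains the only one beyond the scatter. No measurement on hand accounts for this flat result.

Going by these compounds, whether 2-(hydroxycarbamoyl)ethyl or 3-(hydroxycarbamoyl)propyl at the same place would keep the number level stays open, as does the effect of a shorter chain. Also open, on these data alone, are whether the extension behaves alike with trifluoromethyl on the aromatic carbon, and what a carboxylic acid in place of the hydroxycarbamoyl end would give.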